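Series notes: a second chloro entering the aryl ring

A few compounds are considered here, and "the series" means these few. Any claim that something is new, unique, unknown or untested is made for them only; others in the source may bear on it.

Values in an assay on cells for inhibition of Palmitoleoyl-protein carboxylesterase NOTUM variant C330S (Homo sapiens), read by fluorescence, with a stated time of 40 min; on this read-out higher numbers stand for weaker inhibition and lower numbers for stronger inhibition:

Compound 1, `Cc1cc(C(=O)O)c(C)n1-c1ccc(Cl)c(C(F)(F)F)c1`: 2100 nM
Compound 2, `Cc1cc(C(=O)O)c(C)n1-c1ccccc1Cl`: 2300 nM
Compound 3, `Cc1cc(C(=O)O)c(C)n1-c1cccc(C(F)(F)F)c1`: 1500 nM

The three numbers lie within the scatter of one another. Going from compound 3 to compound 1 the change is chloro in place of hydrogen on an aromatic carbon and the step is a 1.4-fold higher number from compound 3 to compound 1 (0.15 log units; within the scatter). The difference between the cores of compound 2 and compound 3 is not broken down here.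

Compound 4, `Cc1cc(C(=O)O)c(C)n1-c1c(Cl)cccc1Cl`, is not yet measured in this assay. Against compound 2 it carries chloro in place of hydrogen on an aromatic carbon. This is the same kind of change as from compound 3 to compound 1, though the surroundings differ: there the entering chloro sat ortho to a trifluoromethyl group and para to a large group, here it sits ortho to a large group and meta to a chloro group. Resting on compound 2 at 2300 nM and on the step of a 1.4-fold higher number from compound 3 to compound 1 (0.15 log units; within the scatter), the expected step to compound 4 is a 1.2-fold lower number from compound 2 to compound 4 (0.06 log units; within the scatter). Compound 4 is estimated at 2000 nM, between 900 nM and 4500 nM.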

Compound 4, half-maximal inhibitory concentration: 2300 nM
Compound 4: middle estimate off by 1.2-fold (0.06 log units), on the low side; the measured number falls inside the stated range.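

In this assay the chloro entering ortho to a large group and meta to a chloro group gives no change at the digits printed from compound 2 to compound 4 (within the scatter) on the core of compound 2. Set beside the same change on the core of compound 3, the two steps cannot be told apart: the same change on two cores in this assay, a 1.4-fold higher number (0.15 log units; within the scatter) from compound 3 to compound 1 and no change at the digits printed (within the scatter) from compound 2 to compound 4, 1.4-fold (0.15 log units) apart, within the scatter of two such steps. This shows that the change carries across these two cores without a step beyond the scatter, but it does not show that it would carry to other cores or ring positions, and it gives no cause.

Open, on these data alone, is whether another group on the aryl ring, such as a methoxy or a nitrile, would move the number beyond the scatter. The carboxylic acid stays in all four compounds, which leaves an amide in its place untested here.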